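Compound 3 to compound 4: a new group on the amide nitrogen

The source may report more compounds than this note shows. Statements on the series, on what has been measured and on what is new or still open speak of the compounds shown alone.

Of the compounds shown here, three sharing one core have been measured in a physicochemical assay for solubility, in phosphate buffer, measured as kinetic solubility, with a stated time of 1 h, at pH 7.4; a lower number here means a less soluble compound, a higher number a more soluble compound. Compound 1 `Cc1cc(C)cc(NC(=O)COc2cc(C)nc3ccc(Cl)cc23)c1` gives 8000 nM. Compound 3 `COc1ccc2nc(C)cc(OCC(=O)Nc3cc(C)ccc3OC)c2c1` gives 9500 nM, the highest of the two numbers, although its gap to compound 1 lies within the scatter. For compound 2 `Cc1cc(C)cc(NC(=O)COc2cc(C)nc3ccc(OCc4ccccc4)cc23)c1` this assay reports only a limit, < 1000 nM. Among the measured compounds shown here, the single measured step, an at least 8.0-fold lower number from compound 1 to compound 2 (0.90 log units; beyond the scatter), puts benzyloxy in place of chloro on an aromatic carbon and so bears on the core, not on the group carried by the amide-type nitrogen. Compound 4 `COc1ccc2nc(C)cc(OCC(=O)Nc3c(C)cncc3C)c2c1` differs from compound 3 exactly there: 3,5-dimethylpyridin-4-yl in place of 2-methoxy-5-methylphenyl on an amide-type nitrogen. For the measured compounds named here, no measured step covers this change, so the expectation rests on compound 3 alone. Compound 4 is expected to give 15000 nM, within 6000 nM to 40000 nM. The expected step of a 1.6-fold higher number from compound 3 to compound 4 (0.20 log units; within the scatter) is thus small and uncertain.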

Compound 4, solubility: 12000 nM
Compound 4: middle estimate off by 1.3-fold (0.10 log units), on the high side; low and high end bracket the measured number.
By their numbers in this assay, from the lowest: compounds 1, 3 and 4 (each within the scatter of the next). At a limit, below all of these: compound 2.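

In this assay, putting 3,5-dimethylpyridin-4-yl in place of 2-methoxy-5-methylphenyl gives a 1.3-fold higher number from compound 3 to compound 4 (0.10 log units; within the scatter), so this exchange of rings on the amide-type nitrogen leaves no readable difference. Among the compounds shown here, the earlier step lay on the core, which makes this the first reading at this position. Nothing at hand bears on this step, and no cause can be given for it. Still open, from the compounds shown here alone, is whether an amine or a carboxylic acid on that ring, or a longer chain in its place, would move the number in this assay beyond the scatter.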